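From 2,3-dimethoxyphenyl to naphthalen-2-yl on the shared core

The source may hold more compounds than are shown below. What is called first, only, known or untested is meant among the compounds shown, and "the series" means these compounds.

Measured compounds, all read in a functional assay on A549 cells (Homo sapiens) for inhibition, read by MTT assay, with a stated time of 48 h (on this read-out lower numbers stand for stronger inhibition and higher numbers for weaker inhibition), and given here by structure and value:

Compound 1 `Oc1ccc(C(c2c[nH]c3ccc(Br)cc23)c2c[nH]c3ccc(Br)cc23)cc1` gives 9000 nM
Compound 2 `COc1ccc(C(c2c[nH]c3ccc(Br)cc23)c2c[nH]c3ccc(Br)cc23)cc1` gives 10000 nM
Compound 3 `COc1cccc(C(c2c[nH]c3ccc(Br)cc23)c2c[nH]c3ccc(Br)cc23)c1OC` gives 100000 nM

Compound 3 has the highest number of the three and so the weakest inhibition, since both of its steps lie beyond the scatter: an 11-fold higher number from compound 1 to compound 3 (1.05 log units; beyond the scatter) and a 10-fold higher number from compound 2 to compound 3 (1.00 log units; beyond the scatter) are the two in question. Compounds 1 and 2 cannot be told apart, with a 1.1-fold higher number from compound 1 to compound 2 (0.05 log units; within the scatter) as the step between them.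

Compound 4 `Brc1ccc2[nH]cc(C(c3ccc4ccccc4c3)c3c[nH]c4ccc(Br)cc34)c2c1` has not yet been measured. It carries naphthalen-2-yl in place of 2,3-dimethoxyphenyl on a saturated chain carbon bound to two aromatic carbons.

Among the compounds with values here, the two large steps to compound 3 show that the group at this place can move the number, and compound 3 is the high outlier among only three compounds. Within the data shown here, no measured compound carries naphthalen-2-yl, so the size remains uncertain. The expected step is a 5.0-fold lower number from compound 3 to compound 4 (0.70 log units; beyond the scatter) and it points to a lower number, back towards compounds 1 and 2 but probably not all the way. For compound 4 the estimate is 20000 nM with an expected range from 6000 nM to 80000 nM in this reading.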

Compound 4, half-maximal inhibitory concentration: 8500 nM
Compound 4: middle estimate off by 2.4-fold (0.37 log units), on the high side; low and high end bracket the measured number.
By their numbers in this assay, from the lowest: compounds 4, 1 and 2 (each within the scatter of the next); then compound 3.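

In this assay, naphthalen-2-yl in place of 2,3-dimethoxyphenyl on the saturated chain carbon bound to two aromatic carbons gives a 12-fold lower number from compound 3 to compound 4 (1.07 log units; beyond the scatter), even though the two groups have the same heavy-atom count, so that count alone does not set the number at this position. Compared with the groups of the two other compounds, naphthalen-2-yl gives a 1.1-fold lower number from compound 1 to compound 4 (0.02 log units; within the scatter) and a 1.2-fold lower number from compound 2 to compound 4 (0.07 log units; within the scatter), which places compounds 1, 2 and 4 level in this assay although naphthalen-2-yl has no oxygen and no hydrogen-bond acceptors. Oxygen on the group at this position is therefore not needed to reach this level of inhibition, and among these four compounds only compound 3 stands apart from the rest.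

Nothing available here explains why compound 3 differs from the other three compounds. As far as these compounds go, it remains open whether the high number of compound 3 follows from the two methoxy groups together or from where they sit, and how a group such as an amine or a carboxylic acid on the aromatic ring at this position would read.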